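Swapping the aryl group on the carbonyl carbon once more

The compounds below may be only part of what the source reports. "The series", "measured", "known", "first", "only" and "open" are said of these compounds alone.

Measured so far:
compound 1, `CCOc1ccc(C(=O)/C=C/c2c(/C=C/c3ccc(OC)cc3)cc(OC)cc2OC)cc1`, 6.4 ug/mL
compound 2, `COc1ccc(/C=C/c2cc(OC)cc(OC)c2/C=C/C(=O)c2ccccc2C)cc1`, 6.1 ug/mL
compound 3, `COc1ccc(/C=C/c2cc(OC)cc(OC)c2/C=C/C(=O)c2ccc(Br)cc2)cc1`, 6.5 ug/mL

In a functional assay on B16-F10 cells (Mus musculus) for antiproliferative activity, read by MTT assay, with a stated time of 48 h (a higher number here means a weaker inhibitor, a lower number a stronger inhibitor), compound 3 gives the highest of the three numbers, but its nearest neighbour compound 1 and its furthest neighbour compound 2 both lie within the scatter, so no order among them is claimed. Compound 4, `COc1ccc(/C=C/c2cc(OC)cc(OC)c2/C=C/C(=O)c2ccc(C)cc2C)cc1`, differs from compound 3 in one place: 2,4-dimethylphenyl in place of 4-bromophenyl on a carbonyl carbon. The earlier steps shown here that bear on this change, a 1.0-fold lower number from compound 1 to compound 2 (0.02 log units; within the scatter) and a 1.1-fold higher number from compound 2 to compound 3 (0.03 log units; within the scatter), were both within the scatter, as was a 1.0-fold higher number from compound 1 to compound 3 (0.01 log units; within the scatter). A step of about the same size, no change at the digits printed from compound 3 to compound 4 (within the scatter), is therefore expected, with no change beyond the scatter. Compound 4 is estimated at 6.5 ug/mL, within a range from 3.5 ug/mL to 12 ug/mL.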

Compound 4, half-maximal inhibitory concentration: 4 ug/mL
Estimate against measurement, compound 4: 1.6-fold (0.21 log units) above, and the stated range covers the measured number.
By their numbers in this assay, from the lowest: compounds 4, 2, 1 and 3 (each within the scatter of the next).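

In this assay, adding a methyl to the aryl group on the carbonyl carbon gives a step that stays within the scatter (a 1.5-fold lower number from compound 2 to compound 4 (0.18 log units; within the scatter)), and so do the two exchanges of the whole aryl group (a 1.6-fold lower number from compound 3 to compound 4 (0.21 log units; within the scatter)) and (a 1.6-fold lower number from compound 1 to compound 4 (0.20 log units; within the scatter)). All four aryl groups shown at this place therefore give numbers that cannot be told apart, so no order among them can be read. Nothing here explains these numbers.

From the compounds shown here alone, it remains open whether a phenyl group carrying an amine or a carboxylic acid, or a longer chain in place of the aryl group, would move the number beyond the scatter.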